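Halogen swap on the benzoyl ring: chloro to fluoro

The source may hold more compounds than are shown below. What is called first, only, known or untested is meant among the compounds shown, and "the series" means these compounds.

Compound 2 `Cc1ccc(OCC(=O)NNC(=O)c2cc3ccccc3oc2=O)c(C(=O)c2ccc(Cl)cc2)c1` carries the shared core with a 4-chlorophenyl on its carbonyl carbon. In a functional assay on DLA cells (Mus musculus) for cytotoxicity, read by MTT assay, with a stated time of 48 h (on this read-out lower numbers stand for stronger inhibition and higher numbers for weaker inhibition), compound 2 gives 59100 nM, the highest of the two numbers recorded so far. Its nearest neighbour is compound 1 `Cc1ccc(OCC(=O)NNC(=O)c2cc3ccccc3oc2=O)c(C(=O)c2ccccc2Br)c1`, which in this assay gives 10000 nM; the step of a 5.9-fold higher number from compound 1 to compound 2 (0.77 log units; beyond the scatter) came with 4-chlorophenyl in place of 2-bromophenyl on a carbonyl carbon.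

Compound 3 `Cc1ccc(OCC(=O)NNC(=O)c2cc3ccccc3oc2=O)c(C(=O)c2ccc(F)cc2)c1` has not been measured. It differs from compound 2 by fluoro in place of chloro on an aromatic carbon. Among the compounds with values here, no measured step exchanges one halogen for another on this ring, so the single recorded step from compound 1 to compound 2 speaks only indirectly to the change: it shows that the benzoyl substituent can move the number beyond the scatter, but not which way a chloro-to-fluoro exchange would go. On that basis a step of a 1.2-fold lower number from compound 2 to compound 3 (0.07 log units; within the scatter) is expected, that is, none beyond the scatter. Compound 3 is therefore estimated to give about 50000 nM in this assay, within a range from 15000 nM to 200000 nM.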

Compound 3, half-maximal inhibitory concentration: 43400 nM
The estimate for compound 3 lay 1.2-fold (0.06 log units) above the measured number; low and high end bracket the measured number.
By their numbers in this assay, from the lowest: compound 1; then compounds 3 and 2 (each within the scatter of the next).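

In this assay, within the data shown here, this is the first exchange of one halogen for another on the aromatic carbon para to a large group, and it gives a 1.4-fold lower number from compound 2 to compound 3 (0.13 log units; within the scatter), so the two halogens cannot be told apart at this place. The second step, a 4.3-fold higher number from compound 1 to compound 3 (0.64 log units; beyond the scatter), shows with 4-fluorophenyl what 4-chlorophenyl had already shown, so the separation from compound 1 beyond the scatter now holds for both of these groups, though the size of each step is modest. Nothing available here accounts for either step.

Going by these compounds, it remains open whether the separation from compound 1 follows from the bromo itself or from where it sits on the ring, as these two differences are joined in both steps that start from compound 1. On these data alone, it is also open whether a group of another kind on this aromatic carbon, such as an amine or a carboxylic acid, would move the number beyond the scatter, as the exchange of chloro for fluoro does not.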